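Isopropylamino for (phenylsulfanyl)methyl on a carbonyl carbon

The source may hold more compounds than are shown below. What is called first, only, known or untested is meant among the compounds shown, and "the series" means these compounds.

Measured in a functional assay with Oryctolagus cuniculus as the target (on this read-out higher numbers stand for weaker inhibition and lower numbers for stronger inhibition), each value being a limit and not a number:
Compound 1 `CC/N=C(/N)Nc1nc(-c2ccc(OC)cc2)c(-c2ccc(OC)cc2)s1`: > 100 nM
Compound 2 `COc1ccc(-c2nc(/N=C(\N)[N+]3(C)CCCCC3)sc2-c2ccc(OC)cc2)cc1`: > 1000 nM
Compound 3 `COc1ccc(-c2nc(CNC(=O)CSc3ccccc3)sc2-c2ccc(OC)cc2)cc1`: < 100 nM

Compound 3 stands at the limit of < 100 nM in this assay, at which 1 of the 3 values shown sits, which is a limit and not a number. The two further values shown are limits as well, so no exact gap can be read between any of the three compounds.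

The next compound, compound 4 `COc1ccc(-c2nc(CNC(=O)NC(C)C)sc2-c2ccc(OC)cc2)cc1`, carries the change (isopropylamino in place of (phenylsulfanyl)methyl on a carbonyl carbon). In words, isopropylamino stands in place of (phenylsulfanyl)methyl on a carbonyl carbon, whose other neighbour is an amide-type nitrogen.

For the measured compounds named here, only one measured step exists, a step that the two limits leave unreadable from compound 1 to compound 2. It exchanges a group on an aromatic carbon, not on a carbonyl carbon, and its size cannot be read, so it gives no guidance here. Going by the values given here, no measured pair varies the group on the carbonyl carbon. Among the compounds with values here, the only anchor is compound 3, with its limit of < 100 nM.

Compound 4 is therefore expected to stay close to that limit in this assay, with no step in either direction expected beyond the scatter. The expected step is a step that the limit leaves unreadable from compound 3 to compound 4. For compound 4 the estimated value is 80 nM, with an expected range of 15 nM to 400 nM.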

Compound 4, half-maximal inhibitory concentration: 42 nM
Compound 4: the middle estimate sits 1.9-fold (0.28 log units) above what was measured; the measured number falls inside the stated range.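

In this assay, for the compounds shown here, compound 4 gives 42 nM, the only exact number among the four compounds, and it shows that this position does not need the aromatic ring or the sulfur of (phenylsulfanyl)methyl to reach a value of this size. The group on the aromatic carbon also counts, with an at least 23-fold lower number from compound 2 to compound 4 (1.37 log units; beyond the scatter) and an at least 2.3-fold lower number from compound 1 to compound 4 (0.37 log units; beyond the scatter), so the urea-type chain that carries isopropylamino compares well with both groups in those compounds. Whether isopropylamino itself moves the value relative to (phenylsulfanyl)methyl cannot be read, because compound 3 carries only a limit and no number: the limit of < 100 nM in this assay, at which 1 of the 4 values shown sits.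

Going by these compounds, what remains open is how much room the carbonyl carbon allows, since a single alkylamino group says little about the trend that methylamino, a longer chain such as n-butylamino, or a cyclic amine such as piperidine would give in this assay. On these data alone, it is equally open whether the amide-type nitrogen's hydrogen matters, which an N-methyl version of compound 4 would address.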